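Adding a third methoxy to compound 3

This account rests on a few compounds, and the source may have more. Where it says the series, first, only, none or still open, it means among the compounds named here.

In a functional assay on A549 cells (Homo sapiens) for inhibition, read by sulforhodamine B assay (on this read-out lower numbers stand for stronger inhibition of growth and higher numbers for weaker inhibition of growth), compound 3 (`COc1ccc(-c2ccc(-c3ccc(-c4nc5c(O)cccc5[nH]4)cc3)cc2)cc1OC`) gives 1310 nM. Compound 2 (`COc1cc(-c2ccc(-c3ccc(-c4nc5ccccc5[nH]4)cc3)cc2)cc(OC)c1OC`) gives 2110 nM, within the scatter of compound 3. Compound 1 (`COc1cc(-c2ccc(-c3ccc(-c4nc5cc(C)ccc5[nH]4)cc3)cc2)cc(OC)c1OC`) is reported only as a limit, < 100 nM.

Compound 4 (`COc1cc(-c2ccc(-c3ccc(-c4nc5c(O)cccc5[nH]4)cc3)cc2)cc(OC)c1OC`) comes from compound 3 through methoxy in place of hydrogen on an aromatic carbon, ortho to a methoxy group and meta to a large group.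

Among the measured compounds shown here, the only measured step that bears on this is an at least 21-fold higher number from compound 1 to compound 2 (1.32 log units; beyond the scatter). It is large, but it is hydrogen in place of methyl, a different exchange, so it only shows that one small change can move this assay far. For the measured compounds named here, no measured step adds a methoxy, so no shift beyond the scatter is expected in either direction, and any small move is guessed to be towards a lower number. The expected change is a 1.3-fold lower number from compound 3 to compound 4 (0.12 log units; within the scatter). For compound 4 the estimate is 1000 nM, with an expected range of 250 nM to 3000 nM.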

Compound 4, concentration for 50% growth inhibition: < 100 nM
Compound 4 was reported as a limit; the forecaster's own chance of this, stated with the estimate: 10%; middle value at least 10-fold (1.00 log units) from the limit.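

In this assay, among the compounds shown here, a methoxy at this position, ortho to a methoxy group and meta to a large group, is the first addition to move the number beyond the scatter: an at least 13-fold lower number from compound 3 to compound 4 (1.11 log units; beyond the scatter). Within the same trimethoxy-bearing frame, the hydroxy exchange on the benzimidazole side also gives a large move, an at least 21-fold lower number from compound 2 to compound 4 (1.32 log units; beyond the scatter), so a large step is no longer confined to the methyl exchange seen earlier. The value of compound 4 is a limit, so the full size of both steps cannot be given: the limit of < 100 nM in this assay, at which 2 of the 4 values shown sit.

Going by these compounds, the step between compound 1 and compound 4 cannot be read, and their order remains open. On these data alone, whether an amine or a longer chain at the methoxy position would keep the number this low also remains open.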